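The source may report more compounds than this note shows. Statements on the series, on what has been measured and on what is new or still open speak of the compounds shown alone.

Measured compounds:
Compound 1 `COc1ccc(CSc2nnc(-c3cc(OC)c(OC)c(OC)c3)n2-c2ccc(OC)cc2)cc1`: in a functional assay on PC-3 cells (Homo sapiens) for inhibition, read by MTT assay, with a stated time of 48 h (on this read-out higher numbers stand for weaker inhibition and lower numbers for stronger inhibition), compound 1 gives 40300 nM.
Compound 2 `COc1ccc(-n2c(SCc3ccc(F)cc3)nnc2-c2cc(OC)c(OC)c(OC)c2)cc1`: in this assay compound 2 gives 35000 nM.
Compound 3 `COc1ccc(C(=O)CSc2nnc(-c3cc(OC)c(OC)c(OC)c3)n2-c2ccc(N(C)C)cc2)cc1`: in this assay compound 3 gives 22000 nM.

Compound 1 and compound 2 differ by fluoro in place of methoxy on an aromatic carbon, and that change made a 1.2-fold lower number from compound 1 to compound 2 (0.06 log units; within the scatter). The difference between the core of compound 1 and the core of compound 3 is not broken down here. Compound 4 `COc1cc(-c2nnc(SCC(=O)c3ccc(F)cc3)n2-c2ccc(N(C)C)cc2)cc(OC)c1OC` is still to be measured; it differs from compound 3 by fluoro in place of methoxy on an aromatic carbon, the same change, at a place described in the same words. Because the earlier step was a 1.2-fold lower number from compound 1 to compound 2 (0.06 log units; within the scatter), compound 4 is expected to sit close to compound 3, with an estimated step of a 1.2-fold lower number from compound 3 to compound 4 (0.06 log units; within the scatter) in this assay. Compound 4 is therefore estimated at 19000 nM, between 10000 nM and 40000 nM.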

Compound 4, half-maximal inhibitory concentration: 42300 nM
Compound 4: the middle estimate sits 2.2-fold (0.35 log units) below what was measured, and the stated range ends below it.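

In this assay, fluoro in place of methoxy gave a 1.9-fold higher number from compound 3 to compound 4 (0.28 log units; within the scatter). Set beside the earlier step, the change does not read differently on the two cores: the same change on two cores in this assay, a 1.2-fold lower number (0.06 log units; within the scatter) from compound 1 to compound 2 and a 1.9-fold higher number (0.28 log units; within the scatter) from compound 3 to compound 4, 2.2-fold (0.35 log units) apart, within the scatter of two such steps. On both cores the step stays within the scatter, so these two pairs show no measurable effect of the change and no measurable dependence on the core, but they do not establish that the effect is absent or that it would carry over identically to other cores in the series.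

The compounds shown leave open how other groups at this place, such as chloro, trifluoromethyl or an amine, would read. They also leave open whether a longer chain carrying this ring would alter the picture.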